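Cyano for dimethylamino on a directly attached phenyl

A few compounds are considered here, and "the series" means these few. Any claim that something is new, unique, unknown or untested is made for them only; others in the source may bear on it.

Compound 1 `Cc1ccc(-c2noc(C3CCc4c(nnn4C(C)(C)C)C3)n2)cn1` gives 1580 nM
Compound 2 `CC(C)(C)n1nnc2c1CCC(c1nc(Cc3ccc(F)cc3)no1)C2` gives 20 nM
Compound 3 `CN(C)c1ccc(-c2noc(C3CCc4c(nnn4C(C)(C)C)C3)n2)cc1` gives 1000 nM

These three compounds share one core and differ only in the aromatic group attached to it. In a functional assay on U2OS cells for positive allosteric modulation of metabotropic glutamate receptor 5 (Homo sapiens), read by calcium flux, in the presence of a further agent that is not named here (a lower number here means that less compound is needed, a higher number that more compound is needed for the effect), compound 3 holds the second highest of the three numbers. Its nearest neighbour is compound 1: the step of a 1.6-fold lower number from compound 1 to compound 3 (0.20 log units; within the scatter) lies within the scatter, so the two cannot be told apart. Its furthest neighbour is compound 2: the step of a 50-fold higher number from compound 2 to compound 3 (1.70 log units; beyond the scatter) is large, as is a 79-fold lower number from compound 1 to compound 2 (1.90 log units; beyond the scatter), and both of these large steps involve the 4-fluorobenzyl of compound 2.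

Compound 4 `CC(C)(C)n1nnc2c1CCC(c1nc(-c3ccc(C#N)cc3)no1)C2` is not yet measured. Compared with compound 3 the change is cyano in place of dimethylamino on an aromatic carbon. Within the data shown here, no measured step swaps one group for another on a directly attached phenyl ring, so no step bears on this change directly. Among the measured compounds shown here, the only comparison between two directly attached aromatic rings, compound 1 against compound 3, changed little. On that basis the step of a 1.2-fold higher number from compound 3 to compound 4 (0.08 log units; within the scatter) is expected to stay within the scatter, in no clear direction. Compound 4 is therefore estimated at 1200 nM in this assay, with a likely range from 300 nM to 5000 nM.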

Compound 4, half-maximal effective concentration: 79.4 nM
Beside the measured number, compound 4's estimate is 15-fold (1.18 log units) above it; the whole stated range lies above it.
By their numbers in this assay, from the lowest: compound 2; then compound 4; then compounds 3 and 1 (each within the scatter of the next).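

In this assay the step of a 13-fold lower number from compound 3 to compound 4 (1.10 log units; beyond the scatter) shows that the group on the directly attached phenyl ring, on an aromatic carbon para to a large group, can strongly change the number while the rest of the molecule stays the same. The earlier comparison between two directly attached rings had changed little, and both large steps had involved the 4-fluorobenzyl of compound 2. The step of a 20-fold lower number from compound 1 to compound 4 (1.30 log units; beyond the scatter) now shows that a directly attached ring need not give a high number, although the step of a 4.0-fold higher number from compound 2 to compound 4 (0.60 log units; beyond the scatter) leaves compound 2 with the lowest number of the four.

The compounds shown leave open how other groups at this place on the phenyl ring would compare with cyano, such as a chlorine atom, a methoxy group or a carboxylic acid, and whether cyano on the ring of the 4-fluorobenzyl group would lower the number further. Nothing given here explains why cyano and dimethylamino differ so much in this assay.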